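Amino Swapped for Hydroxy, with Cell Tolerance at the Limit

The source may hold more compounds than are shown below. What is called first, only, known or untested is meant among the compounds shown, and "the series" means these compounds.

Within the data shown here, in an ADME assay on Vero cells (Chlorocebus sabaeus) for cytotoxicity, read by WST assay (a higher number here means that more compound is tolerated, a lower number that less compound is tolerated), every compound measured so far sits at the top of what the assay can read. Compound 1 `Nc1ccc2c(=O)[nH]c(Nc3cc(F)cc(F)c3)nc2c1` gives > 25000 nM, which is a limit rather than a number. Compound 2 `O=c1[nH]c(Nc2cc(F)cc(F)c2)nc2cc(O)ccc12` gives > 25000 nM, again a limit. Compound 3 `Nc1ccc2c(=O)[nH]c(Nc3cc(Cl)cc(Cl)c3)nc2c1` likewise gives > 25000 nM, also a limit. Compound 2 arises from compound 1 by hydroxy in place of amino on an aromatic carbon; because both ends are limits, this gives a step that the two limits leave unreadable from compound 1 to compound 2. How the core of compound 3 differs from that of compound 1 is not broken down here. Compound 4 `O=c1[nH]c(Nc2cc(Cl)cc(Cl)c2)nc2cc(O)ccc12` arises from compound 3 by the same change, (hydroxy in place of amino on an aromatic carbon). Among the measured compounds shown here, because the limit of > 25000 nM in this assay, at which 3 of the 3 values shown sit, holds all three values so far, a step that the limit leaves unreadable from compound 3 to compound 4 is expected in this assay. Compound 4 is therefore estimated at 40000 nM, most likely reported once more only as a limit.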

Compound 4, half-maximal cytotoxic concentration: > 25000 nM
Compound 4: no number, only a limit; the forecaster's own chance of this, stated with the estimate: 85%; the middle value lies beyond the limit too.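

No step can be read between compound 3 and compound 4, as both stop at the same limit: the limit of > 25000 nM in this assay, at which 4 of the 4 values shown sit.

The compounds shown leave open how much compound is actually tolerated in this assay, and whether hydroxy in place of amino makes any difference there.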